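The source may hold more compounds than are shown below. What is called first, only, known or untested is meant among the compounds shown, and "the series" means these compounds.

Measured in an ADME assay on microsomes from liver (Mus musculus) for metabolic stability, read by LC-MS, with a stated time of 10 min; on this read-out higher numbers stand for a more stable compound and lower numbers for a less stable compound:
compound 1 `CCCN(C[C@H]1Cc2c(cccc2N2CCNCC2)CN1)[C@H]1CCCc2cccnc21`: 87.4%
compound 2 `CN(C[C@H]1Cc2c(cccc2N2C[C@@H]3C[C@H]2CN3)CN1)[C@H]1CCCc2cccnc21`: 36.3%
compound 3 `c1cnc2c(c1)CCC[C@@H]2N(CC1CCCCC1)C[C@H]1Cc2c(cccc2N2CCNCC2)CN1`: 85.6%

Compound 2 gives the lowest of the three numbers; its gaps to compound 3 and to compound 1 both lie beyond the scatter. Compound 4 `CC(C)N1CCN(c2cccc3c2C[C@H](CN(C)[C@H]2CCCc4cccnc42)NC3)CC1` is not yet measured. It differs from compound 2 in one place: a group of 9 heavy atoms (7 carbon, 2 nitrogen; one six-membered non-aromatic ring with 2 hetero atoms) in place of a group of 7 heavy atoms (5 carbon, 2 nitrogen; 2 five-membered non-aromatic rings with 1 hetero atom each), on an aromatic carbon. Within the data shown here, no measured step covers this change. Among the measured compounds shown here, the single measured step, a number 1.8 percentage points lower from compound 1 to compound 3 (within the scatter), sits at another place, on a saturated chain carbon bound to an amine nitrogen, and lies within the scatter, so it says nothing direct about the aromatic carbon. A step upward from compound 2 is expected in this assay because compound 1 gives 87.4% and compound 3 gives 85.6% with a six-membered ring of the same kind on that aromatic carbon, while compound 2 gives 36.3% with the two five-membered rings; the size is uncertain since the methyl on the amine nitrogen is kept from compound 2. The expected step is a number 28.7 percentage points higher from compound 2 to compound 4 (beyond the scatter). Compound 4 is therefore estimated at 65%, within a range from 40% to 88%.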

Compound 4, percent of the compound remaining: 15.1%
Compound 4: the middle estimate sits 49.9 percentage points above what was measured; the measured number lies below the stated range.
By their numbers in this assay, from the lowest: compound 4; then compound 2; then compounds 3 and 1 (each within the scatter of the next).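

In this assay, 4-isopropylpiperazin-1-yl on this aromatic carbon gives a number 21.2 percentage points lower from compound 2 to compound 4 (beyond the scatter), so this exchange moves the number down, not up. With the methyl on the amine nitrogen kept, a six-membered non-aromatic ring with 2 hetero atoms at this place therefore does not guarantee a high number, and the values of compound 1 and compound 3 cannot be credited to that ring type alone. Nothing available explains the size or direction of this step.

The exchange replaces the whole group at once, with 1 hydrogen-bond donor leaving and 0 entering, so the ring and the isopropyl on its nitrogen remain inseparable here. Still open, going by these compounds, is how the number would respond to an acetyl in place of that isopropyl, or to a morpholine ring on the same aromatic carbon.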